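Swapping the Aromatic Ring on the Amide of Compound 1

This account rests on a few compounds, and the source may have more. Where it says the series, first, only, none or still open, it means among the compounds named here.

In a functional assay on MCF7 cells (Homo sapiens) for antiproliferative activity, read by MTT assay, with a stated time of 72 h (a lower number here means a stronger inhibitor, a higher number a weaker inhibitor), compound 1 `CCN1CCN(c2cc(C)c3cc(NC(=O)c4ccc(OC)cc4)ccc3n2)CC1` gives 7690 nM, the highest of the two numbers measured here, while compound 2 `Cc1cc(N2CCN(C(C)C)CC2)nc2ccc(NC(=O)c3ccc(Cl)c(Cl)c3)cc12` gives 1710 nM, a gap beyond the usual scatter. Compound 3 `CCN1CCN(c2cc(C)c3cc(NC(=O)c4ccc[nH]4)ccc3n2)CC1` has not yet been measured; it differs from compound 1 by 1H-pyrrol-2-yl in place of 4-methoxyphenyl on a carbonyl carbon. Going by the values given here, no measured pair shows this change, so the expected step of a 1.3-fold lower number from compound 1 to compound 3 (0.11 log units; within the scatter) is small and may stay within the scatter. Compound 3 is therefore expected to give about 6000 nM, estimated between 2000 nM and 18000 nM in this assay.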

Compound 3, half-maximal inhibitory concentration: 14700 nM
The estimate for compound 3 lay 2.5-fold (0.39 log units) below the measured number, within the range that was stated.
By their numbers in this assay, from the lowest: compound 2; then compounds 1 and 3 (each within the scatter of the next).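

In this assay, going by these compounds alone, the earlier compounds offered no step that changes this group alone, and here 1H-pyrrol-2-yl in place of 4-methoxyphenyl on a carbonyl carbon gives a 1.9-fold higher number from compound 1 to compound 3 (0.28 log units; within the scatter). At this position, then, a five-membered aromatic ring with a hydrogen-bond donor and a six-membered aromatic ring of carbon only cannot be told apart in this measurement. Nothing available explains this result.

Still open, from the compounds shown here alone, is whether a plain phenyl, or a phenyl ring carrying an amine or a carboxylic acid, on the same carbonyl carbon would move the number beyond the scatter.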